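Swapping a methyl for a bromo on compound 3

The compounds below may be only part of what the source reports. "The series", "measured", "known", "first", "only" and "open" are said of these compounds alone.

Compound 1 `Cc1ccc(OCCn2ccc(=O)n(Cc3cc(C)cc(C)c3)c2=O)cc1`: > 343000 nM, a limit of the assay and not a number
Compound 2 `Cc1ccc(OCCn2ccc(=O)n(C(C)c3ccccc3)c2=O)cc1`: 132000 nM
Compound 3 `Cc1cc(C)cc(Cn2c(=O)ccn(C/C=C/c3ccccc3)c2=O)c1`: 257000 nM

All three compounds were tested in an ADME assay on MT4 cells (Homo sapiens) for cytotoxicity, read by MTT assay, with a stated time of 4 days; a higher number here means that more compound is tolerated, a lower number that less compound is tolerated. Compound 3 gives 257000 nM. Compound 2 gives 132000 nM, which lies within the usual scatter of compound 3, so the two cannot be ranked.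

Compound 4 `Cc1cc(Br)cc(Cn2c(=O)ccn(C/C=C/c3ccccc3)c2=O)c1` differs from compound 3 in one place: bromo in place of methyl on an aromatic carbon. The 3,5-dimethylphenyl group becomes 3-bromo-5-methylphenyl.

Going by the values given here, no measured step makes this exact swap. The closest one is an at least 2.5-fold lower number from compound 1 to compound 2 (0.41 log units; beyond the scatter), which lies beyond the scatter and also alters the 3,5-dimethylbenzyl group, though by replacing it with 1-phenylethyl. The other is an at least 1.3-fold lower number from compound 1 to compound 3 (0.12 log units; that floor lies within the scatter), a change made elsewhere in the molecule, and its floor lies within the scatter. Both steps start from compound 1 and so rest on (the limit of > 343000 nM in this assay, at which 1 of the 3 values shown sits); they give minimum sizes only.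

With so little direct evidence, only a slight fall in this assay is expected, and no step beyond the scatter. The expected step is a 1.4-fold lower number from compound 3 to compound 4 (0.13 log units; within the scatter). For compound 4 the estimate is 190000 nM, with an expected range from 90000 nM to 310000 nM.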

Compound 4, half-maximal cytotoxic concentration: 100000 nM
Beside the measured number, compound 4's estimate is 1.9-fold (0.28 log units) above it, and the stated range covers the measured number.
By their numbers in this assay, from the lowest: compounds 4, 2 and 3 (each within the scatter of the next, the first and the last beyond it). At a limit, above all of these: compound 1.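

In this assay, bromo in place of methyl on the 3,5-dimethylphenyl group gives a 2.6-fold lower number from compound 3 to compound 4 (0.41 log units; beyond the scatter). This shows that the aromatic carbon meta to a methyl group is not a silent position: exchanging one heavy atom for another there moves the number beyond the scatter, and the change adds no ring, hydrogen-bond donor, hydrogen-bond acceptor or charge. The only earlier change in this part of the molecule replaced the whole 3,5-dimethylbenzyl group with 1-phenylethyl, and the new step is the first here to join two real numbers and so to give a size rather than a minimum, since the earlier steps start from a value that is only a limit: the limit of > 343000 nM in this assay, at which 1 of the 4 values shown sits.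

One pair cannot show whether the lower number comes from the arrival of bromo or from the loss of methyl, and nothing here gives a reason for it. On these data alone, a hydrogen, a chloro, a methoxy or an amine at this carbon would help separate those readings, and it remains open whether the same swap lowers the number when the (4-methylphenoxy)methyl group of compound 1 replaces 2-phenylethenyl.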